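Nitro to methyl swap repeated on a second core

A few compounds are considered here, and "the series" means these few. Any claim that something is new, unique, unknown or untested is made for them only; others in the source may bear on it.

Compound 1 `O=C1NN(c2ccc([N+](=O)[O-])cc2)C(=O)C2(CSC3=C2C(=O)c2ncccc2C3=O)N1` gives 2 nM in a functional assay on CCRF-CEM cells (Homo sapiens) for antiproliferative activity, read by MTT assay, with a stated time of 96 h; a higher number here means a weaker inhibitor, a lower number a stronger inhibitor. Going by the values given here, compound 2 `Cc1ccc(N2NC(=O)NC3(CSC4=C3C(=O)c3ncccc3C4=O)C2=O)cc1` differs from it only by methyl in place of nitro on an aromatic carbon; in this assay compound 2 gives 70 nM, so the single measured instance of this change is a 35-fold higher number from compound 1 to compound 2 (1.54 log units; beyond the scatter). Compound 3 `O=C1C2=C(C(=O)c3ncccc31)C1(CS2)NC(=O)N(c2ccc([N+](=O)[O-])cc2)C1=O` sits on a core that is not the same as that of compound 1, and the difference between the two cores is not broken down here. In this assay compound 3 gives 1 nM, a value within the scatter of that of compound 1 and far from that of compound 2. Compound 4 `Cc1ccc(N2C(=O)NC3(CSC4=C3C(=O)c3ncccc3C4=O)C2=O)cc1` is not yet measured; it differs from compound 3 by methyl in place of nitro on an aromatic carbon, the same change, at the same place, that separates compound 1 from compound 2. Among the compounds with values here, a step of about a 35-fold higher number from compound 3 to compound 4 (1.54 log units; beyond the scatter) is expected here, resting on a 35-fold higher number from compound 1 to compound 2 (1.54 log units; beyond the scatter) as the only precedent, with the width of the range reflecting that one pair alone supports it. Compound 4 is therefore estimated at 35 nM in this assay, most likely between 10 nM and 120 nM.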

Compound 4, half-maximal inhibitory concentration: 20 nM
Compound 4: the middle estimate sits 1.8-fold (0.24 log units) above what was measured; the range from low to high includes it.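

In this assay, methyl in place of nitro on the core of compound 3 gives a 20-fold higher number from compound 3 to compound 4 (1.30 log units; beyond the scatter), so the change also costs a large amount on a second core. The two pairs agree in direction, and their sizes do not separate: the same change on two cores in this assay, a 35-fold higher number (1.54 log units; beyond the scatter) from compound 1 to compound 2 and a 20-fold higher number (1.30 log units; beyond the scatter) from compound 3 to compound 4, 1.8-fold (0.24 log units) apart, within the scatter of two such steps

For this series, the change from 4-nitrophenyl to 4-methylphenyl can therefore be carried between these two cores with a similar expected step, but two pairs do not show that it would hold on any further core, at another place on the aromatic ring, or for any other swap of groups, and they do not explain why the step arises.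

The compounds shown hold only nitro and methyl at this place, so how an amine, a carboxylic acid or a chlorine atom there would read in this assay stays open. As far as these compounds go, whether a group exists that matches nitro on both cores, and whether these steps hold in other cell lines, also remains open.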